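Chain extension in a triazole-linked amino sugar series

This account rests on a few compounds, and the source may have more. Where it says the series, first, only, none or still open, it means among the compounds named here.

Compound 1 `CCCCCCCCCCCCCCCCn1cc(COC[C@@H]2OC[C@H](N)[C@@H]2O)nn1` and compound 2 `CCCCCCCCCCCCCCCCCCn1cc(COC[C@@H]2OC[C@H](N)[C@@H]2O)nn1` share one core, and compound 3 `CCCCCCCCCCCCn1cc(COC[C@@H]2OC[C@H](N)[C@H]2O)nn1` carries the other core found in this set; compound 4 `CCCCCCCCCCCCCCn1cc(COC[C@@H]2OC[C@H](N)[C@H]2O)nn1` is built on the core of compound 3 and has not yet been measured. In a functional assay on MCF7 cells (Homo sapiens) for antiproliferative activity, read by MTT assay, with a stated time of 48 h (on this read-out lower numbers stand for stronger inhibition and higher numbers for weaker inhibition), compound 1 gives 3300 nM, compound 2 gives 7580 nM and compound 3 gives 2620 nM. The change from compound 1 to compound 2 is ethyl in place of hydrogen on a saturated chain carbon, ten or more bonds along the chain from an aromatic nitrogen and it produced a 2.3-fold higher number from compound 1 to compound 2 (0.36 log units; beyond the scatter). The difference between the two cores, from compound 1 to compound 3, is not broken down here. The change from compound 3 to compound 4 is ethyl in place of hydrogen on a saturated chain carbon, ten or more bonds along the chain from an aromatic nitrogen, the same change as before, at the same place. Among the compounds with values here, on the one precedent, the step is expected to run in the same direction with a 1.7-fold higher number from compound 3 to compound 4 (0.23 log units; within the scatter), because the earlier step read a 2.3-fold higher number from compound 1 to compound 2 (0.36 log units; beyond the scatter), while the unknown core leaves room for a smaller or larger shift. Compound 4 is therefore estimated at 4500 nM, between 2200 nM and 9000 nM.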

Compound 4, half-maximal inhibitory concentration: 2450 nM
The estimate for compound 4 lay 1.8-fold (0.26 log units) above the measured number; the measured number falls inside the stated range.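

In this assay, ethyl in place of hydrogen on the core of compound 3 gives a 1.1-fold lower number from compound 3 to compound 4 (0.03 log units; within the scatter), so compound 3 and compound 4 cannot be told apart on this read-out. The step beyond the scatter on the other core, a 2.3-fold higher number from compound 1 to compound 2 (0.36 log units; beyond the scatter), thus has no counterpart beyond the scatter on this core, yet the two steps cannot be called different: the same change on two cores in this assay, a 2.3-fold higher number (0.36 log units; beyond the scatter) from compound 1 to compound 2 and a 1.1-fold lower number (0.03 log units; within the scatter) from compound 3 to compound 4, 2.5-fold (0.39 log units) apart, within the scatter of two such steps. Carrying this change from one core to the other is therefore neither confirmed nor ruled out, and a single step on each core fixes no general size or direction for it.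

No pair shown differs in the core alone, so the effect of the core itself stays unread. Also open, on these data alone, is whether a longer chain than that of compound 4, or an amine or a carboxylic acid in place of the ethyl, would move the number on the core of compound 3 beyond the scatter.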